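Trimming the Chain: Isopentyl to Butyl on the Core

This account rests on a few compounds, and the source may have more. Where it says the series, first, only, none or still open, it means among the compounds named here.

Compound 3 `CC(C)CCn1c(CN2CCN(C(=O)C3CC3)CC2)nc2ccccc21` gives 70% in an assay on isolated protein for inhibition of aldehyde dehydrogenase 1A1 (Homo sapiens), read by spectrophotometry, tested at 10 uM; a lower number here means less inhibition, a higher number more inhibition at the concentration tested (going by the name of the read-out). On the numbers available it stands second highest of three: compound 2 `Cc1cccc(Cn2c(CN3CCN(C(=O)CC(C)C)CC3)nc3ccccc32)c1` gives 71.4% in this assay, a value within the scatter of compound 3, and compound 1 `Cc1cccc(Cn2c(CN3CCN(C(=O)c4cccs4)CC3)nc3ccccc32)c1` gives 60.8% in this assay, also within the scatter of compound 3. Among the compounds with values here, the only step between compounds that differ in one place is a number 10.6 percentage points higher from compound 1 to compound 2 (beyond the scatter), and it concerns the group on the carbonyl carbon, not the chain on the core.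

Compound 4 `CCCCn1c(CN2CCN(C(=O)C3CC3)CC2)nc2ccccc21` differs from compound 3 by hydrogen in place of methyl on a saturated chain carbon bound to two saturated chain carbons. Within the data shown here, no measured step touches this chain, so the single measured step does not bear on the change, and there is no basis for expecting a shift beyond the scatter in this assay. The expected step is a number 4 percentage points lower from compound 3 to compound 4 (within the scatter). Compound 4 is therefore estimated at 66% in this assay, with a range from 46% to 84%.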

Compound 4, a percentage reported as inhibition, at one concentration (the size of the read-out at that concentration, not a potency): 18.2%
Compound 4: middle estimate off by 47.8 percentage points, on the high side, outside the stated range (below it).
By their numbers in this assay, from the lowest: compound 4; then compounds 1, 3 and 2 (each within the scatter of the next, the first and the last beyond it).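

Taking one methyl off the chain on the shared core, isopentyl to butyl, gives a number 51.8 percentage points lower from compound 3 to compound 4 (beyond the scatter) in this assay, so a change of one heavy atom on a saturated chain carbon bound to two saturated chain carbons can decide much of the inhibition seen at the tested concentration. Within the data shown here, the earlier compounds offered no step at this chain, and their only step, a number 10.6 percentage points higher from compound 1 to compound 2 (beyond the scatter) on the carbonyl carbon, is far smaller. Nothing measured here accounts for the loss.

The compounds shown leave open whether the inhibition follows the branching methyl itself or can be kept with another group on that chain, such as a pentyl chain, a cyclohexylmethyl group or a terminal hydroxyl. They also leave open whether the same change costs as much when the cyclopropyl on the carbonyl is replaced by isobutyl.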